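Epimer of a cyclic peroxide acid, growth inhibition expected

This account rests on a few compounds, and the source may have more. Where it says the series, first, only, none or still open, it means among the compounds named here.

Compound 1 `C=C1CCCC(C)(C)C1CC[C@]1(C)CC[C@H]([C@@H](C)C(=O)OC)OO1`: 4920 nM
Compound 2 `CC1=C(CC/C(C)=C/CC[C@@]2(C)CC[C@@H]([C@H](C)C(=O)O)OO2)C(C)(C)CCC1`: > 100000 nM
Compound 3 `C=C1CCC[C@H]2[C@](C)(CC[C@]3(C)CC[C@H]([C@@H](C)C(=O)O)OO3)[C@@H](C)CC[C@]12C`: 1930 nM

Three cyclic peroxides were tested in a functional assay on A498 cells (Homo sapiens) for inhibition; a lower number here means a stronger inhibitor of growth, a higher number a weaker inhibitor of growth. Compound 1 and compound 3 each give a numerical value in this assay. Compound 2 gives only a limit there, > 100000 nM, which is the limit of > 100000 nM in this assay, at which 1 of the 3 values shown sits. Compound 4 `CC1=C(CC/C(C)=C/CC[C@@]2(C)CC[C@H]([C@H](C)C(=O)O)OO2)C(C)(C)CCC1` is its epimer: the two compounds have the same atoms and bonds and differ only in configuration as drawn: 1 of 4 stereo elements differ; a stereocentre at a saturated ring carbon is drawn S in compound 2 and R in compound 4. For the measured compounds named here, no measured pair shows what such a change in configuration brings, so no direction beyond the scatter can be drawn for compound 2 and compound 4 from the data. Compound 4 is therefore estimated near its epimer, at 80000 nM with a range from 20000 nM to 300000 nM, which would mean an expected step of an at least 1.2-fold lower number from compound 2 to compound 4 (0.09 log units; that floor lies within the scatter) in this assay.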

Compound 4, concentration for 50% growth inhibition: > 5000 nM
Compound 4: a limit, no number; the forecaster's own chance of this, stated with the estimate: 60%; the middle value lies beyond the limit too.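

In this assay, for the compounds shown here, compound 2 and compound 4 each give only a limit, so no step between them can be read. The compounds shown leave open what this single change in configuration does to growth inhibition.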